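Removing the Aryl Trifluoromethyl Group in a Succinimide Piperazine Series

The source may report more compounds than this note shows. Statements on the series, on what has been measured and on what is new or still open speak of the compounds shown alone.

Compound 3 `CCC(C(=O)N1CCN(c2ccc(C(F)(F)F)cc2)CC1)N1C(=O)CCC1=O` sits level with its two measured relatives in a functional assay on the whole organism (strain Swiss) with Mus musculus as the target, in the maximal electroshock model, with a stated time of 0.25 h, at a dose of 300 mg/kg by the intraperitoneal route; a higher number here means a stronger effect of the compound at the dose given, a lower number a weaker effect: compound 3 gives 25%, compound 1 `COCC(C(=O)N1CCN(c2cccc(C(F)(F)F)c2)CC1)N1C(=O)CCC1=O` gives 25%, and compound 2 `CC(C(=O)N1CCN(c2ccc(C(F)(F)F)cc2)CC1)N1C(=O)CCC1=O` gives 25%. Among the compounds with values here, the one single-site step measured, no change at the digits printed from compound 2 to compound 3 (within the scatter), lies within the scatter. Compound 4 `CCC(C(=O)N1CCN(c2ccccc2)CC1)N1C(=O)CCC1=O` differs from compound 3 by hydrogen in place of trifluoromethyl on an aromatic carbon. Within the data shown here, no measured pair changes the aromatic substituent alone, so nothing directly tells the size of this step; the only guide is that every compound so far has landed on the same value, with the trifluoromethyl in either of two ring positions giving no different read-out. The expected step is therefore no change at the digits printed from compound 3 to compound 4 (within the scatter), no change beyond the scatter. Compound 4 is estimated at 25%, between 0% and 50%.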

Compound 4, a percentage reported as activity, at one dose (the size of the read-out at that dose, not a potency): 75%
The estimate for compound 4 lay 50 percentage points below the measured number; the whole stated range lies below it.
By their numbers in this assay, from the lowest: compounds 1, 2 and 3 (each within the scatter of the next); then compound 4.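

In this assay, hydrogen in place of trifluoromethyl on this aromatic carbon gives a number 50 percentage points higher from compound 3 to compound 4 (beyond the scatter). This is the first step beyond the scatter among the compounds shown, so the level read-out of compounds 1, 2 and 3, all of which carry trifluoromethyl, did not extend to its removal. Nothing at hand accounts for the size of this step. As far as these compounds go, whether chlorine, methyl or methoxy on this aromatic carbon would keep the read-out of compound 4 or return it to that of compound 3 stays open. So does whether a change in the saturated chain would still leave the read-out level without trifluoromethyl on the ring.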